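A few compounds are considered here, and "the series" means these few. Any claim that something is new, unique, unknown or untested is made for them only; others in the source may bear on it.

Compound 1 `O=c1nc2oc(C3CC3)c(C#CC3CC3)c2cn1Cc1cn(Cc2ccccc2)nn1` and compound 3 `CCCCCCC#Cc1c(CCCCCC)oc2nc(=O)n(Cc3cn(Cc4ccccc4)nn3)cc12` share a triazole bearing a benzyl group, but the difference between their two cores is not broken down here. In an ADME assay on WI-38 cells (Homo sapiens) for antiproliferative activity, read by MTT assay, with a stated time of 72 h (a lower number here means a stronger inhibitor, a higher number a weaker inhibitor), compound 1 gives 290 nM, while compound 3 gives 23400 nM. Compound 2 `CCCCCCC#Cc1c(CCCCCC)oc2nc(=O)n(Cc3cn(-c4ccc(Cl)cc4)nn3)cc12` differs from compound 3 by 4-chlorophenyl in place of benzyl on an aromatic nitrogen. For compound 2 the result is a limit of the assay, > 100000 nM, and so the step is an at least 4.2-fold higher number from compound 3 to compound 2 (0.63 log units; beyond the scatter); it rests on (the limit of > 100000 nM in this assay, at which 1 of the 3 values shown sits). Compound 4 `O=c1nc2oc(C3CC3)c(C#CC3CC3)c2cn1Cc1cn(-c2ccc(Cl)cc2)nn1` carries the same change on compound 1, (4-chlorophenyl in place of benzyl on an aromatic nitrogen). Within the data shown here, a step of comparable size is expected in this assay from compound 1, so that a 4.5-fold higher number from compound 1 to compound 4 (0.65 log units; beyond the scatter) is estimated, because the only guide is an at least 4.2-fold higher number from compound 3 to compound 2 (0.63 log units; beyond the scatter). Compound 4 is therefore expected to give about 1300 nM, probably between 400 nM and 6000 nM.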

Compound 4, half-maximal inhibitory concentration: 3150 nM
Compound 4: middle estimate off by 2.4-fold (0.38 log units), on the low side; the measured number falls inside the stated range.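

Replacing benzyl with 4-chlorophenyl on an aromatic nitrogen gives a higher number on both cores in this assay, and on the core of compound 1 the step can be read in full as an 11-fold higher number from compound 1 to compound 4 (1.04 log units; beyond the scatter). The direction of the change therefore carries over between the two cores shown. Whether its size also carries over is not shown, since compound 2 stands at a limit of the assay: the same change on two cores in this assay, an at least 4.2-fold higher number (0.63 log units; beyond the scatter) from compound 3 to compound 2 and an 11-fold higher number (1.04 log units; beyond the scatter) from compound 1 to compound 4; the limit leaves it open whether they differ

The compounds shown leave open whether the step comes from the chlorine or from the loss of the carbon link, which plain phenyl or 4-chlorobenzyl on the same nitrogen would separate. They also leave open how this change behaves on cores carrying other groups, such as an amine or a carboxylic acid.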